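Purine series: chloro added between the ring nitrogens

The source may report more compounds than this note shows. Statements on the series, on what has been measured and on what is new or still open speak of the compounds shown alone.

Compound 1 `ClCc1ccc(Cn2cnc3c(Cl)ncnc32)cc1` in a functional assay on SF-539 cells (Homo sapiens) for cytotoxicity, read by sulforhodamine B assay, with a stated time of 48 h; on this read-out lower numbers stand for stronger inhibition of growth and higher numbers for weaker inhibition of growth: 2340 nM
Compound 2 `ClCc1ccccc1Cn1cnc2ncnc(Cl)c21` in this assay: 2340 nM

Compound 1 and compound 2 differ only in where the chloromethyl group sits on the benzyl ring, and in this assay compound 1 gives 2340 nM while compound 2 gives 2340 nM; the two values are level at the digits shown and sit within the scatter of each other, so no ordering between them can be read.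

Compound 3 `ClCc1ccc(Cn2cnc3c(Cl)nc(Cl)nc32)cc1` is not yet measured in this assay. Relative to compound 1 it carries chloro in place of hydrogen on an aromatic carbon, the new chloro sitting between two ring nitrogen atoms of the shared core, meta to the chloro group already present and meta and para to the fused ring. Among the measured compounds shown here, no measured pair shows what such a change does, so the size of the step rests on nothing more than the two values above.

The expectation is therefore a step that stays within the scatter, or at most a slight move toward stronger inhibition of growth, estimated as a 1.3-fold lower number from compound 1 to compound 3 (0.11 log units; within the scatter). Compound 3 is expected to give about 1800 nM in this assay, with a range from 700 nM to 5000 nM.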

Compound 3, concentration for 50% growth inhibition: 17000 nM
Compound 3: the middle estimate sits 9.4-fold (0.98 log units) below what was measured, outside the stated range (above it).
By their numbers in this assay, from the lowest: compounds 1 and 2 (each within the scatter of the next); then compound 3.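

In this assay, chloro in place of hydrogen on the aromatic carbon between two ring nitrogen atoms gives a 7.3-fold higher number from compound 1 to compound 3 (0.86 log units; beyond the scatter), so this place on the shared core is not silent, and the change weakens growth inhibition beyond the scatter. Among the compounds shown here, the earlier pair differed only in where the chloromethyl group sits on the benzyl ring and stayed level, so this is the first step that can be read as a change, and it lies on the core rather than on the benzyl ring. Nothing at hand bears on why one added chlorine atom at this place shifts the number this far.

From the compounds shown here alone, it remains open whether the step belongs to chloro itself or to any group on this carbon, a question that an amine or a methoxy group at the same place would address. Going by these compounds, it is also open whether the same step would appear with the chloromethyl group placed as in compound 2, since the step is known from the compound 1 arrangement alone.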